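Swapping a tert-butyl for an azepane on a pyrazole core

The compounds below may be only part of what the source reports. "The series", "measured", "known", "first", "only" and "open" are said of these compounds alone.

Of the compounds shown here, three share one scaffold and have been tested in a functional assay on cells for antagonist activity at prostaglandin E2 receptor EP1 subtype (Rattus norvegicus), read by fluorescence and calcium flux, with a stated time of 60 s; on this read-out lower numbers stand for stronger inhibition and higher numbers for weaker inhibition. Compound 1 `O=C(O)c1cccc(Cc2c(-c3ccccc3)nn3cc(Br)ccc23)n1` gives 11 nM. Compound 2 `O=C(O)c1cccc(Cc2c(-c3ccco3)nn3cc(Cl)ccc23)n1` gives 1200 nM. Compound 3 `CC(C)(C)c1nn2cc(Cl)ccc2c1Cc1cccc(C(=O)O)n1` gives 48 nM. Among these three numbers compound 3 stands second highest: compound 1 lies nearest to it, with a lower number, while compound 2 lies furthest away, with a higher one. Compound 4 `O=C(O)c1cccc(Cc2c(N3CCCCCC3)nn3cc(Cl)ccc23)n1` has not yet been measured. It differs from compound 3 in one place: azepan-1-yl in place of tert-butyl on an aromatic carbon. Among the compounds with values here, the only measured step at that same position is a 25-fold lower number from compound 2 to compound 3 (1.40 log units; beyond the scatter), which shows how strongly this position can swing the read-out, but it compares two groups that differ from both the tert-butyl and the azepan-1-yl, so no step in the data bears directly on this exchange. He therefore expects a step of a 1.3-fold higher number from compound 3 to compound 4 (0.10 log units; within the scatter) for compound 4, that is, no clear movement beyond the scatter in this assay, with wide uncertainty in either direction. His estimate for compound 4 is 60 nM, with a range from 10 nM to 400 nM.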

Compound 4, half-maximal inhibitory concentration: 1400 nM
Estimate against measurement, compound 4: 23-fold (1.37 log units) below, and the stated range ends below it.
By their numbers in this assay, from the lowest: compound 1; then compound 3; then compounds 2 and 4 (each within the scatter of the next).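

In this assay, the exchange at this carbon next to the ring nitrogen gives a 29-fold higher number from compound 3 to compound 4 (1.46 log units; beyond the scatter), so the tert-butyl result does not carry over to azepan-1-yl, a larger group with a seven-membered non-aromatic ring. With a 1.2-fold higher number from compound 2 to compound 4 (0.07 log units; within the scatter), the azepan-1-yl and furan-2-yl groups stand level, even though one ring is aromatic and the other is not. Among compounds 2, 3 and 4, which differ only at this position, tert-butyl alone stands apart, and both of its steps to the other two lie beyond the scatter.

Nothing measured here explains this result. As far as these compounds go, it remains open whether a smaller cyclic amine such as pyrrolidin-1-yl, an open-chain amine such as diethylamino, or the all-carbon ring cyclohexyl would stand with tert-butyl or with azepan-1-yl.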